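This account rests on a few compounds, and the source may have more. Where it says the series, first, only, none or still open, it means among the compounds named here.

Measured so far:
Compound 1 `COc1ccc2cc(CCCO)oc(=O)c2c1` gives 29.1 ug/mL
Compound 2 `CCCCCOCCCc1cc2ccc(OC)cc2c(=O)o1` gives 28.3 ug/mL
Compound 3 `COc1ccc2c(c1)C(=O)OC(CCCO)C2` gives 132 ug/mL

All three were tested in a functional assay on HT-29 cells (Homo sapiens) for antiproliferative activity, read by sulforhodamine B assay, with a stated time of 48 h; on this read-out lower numbers stand for stronger inhibition of growth and higher numbers for weaker inhibition of growth. Compound 1 and compound 2 share one core, and compound 2 differs from compound 1 only by pentyl in place of hydrogen on an oxygen on a saturated carbon. The step of a 1.0-fold lower number from compound 1 to compound 2 (0.01 log units; within the scatter) shows that this change left the growth inhibition essentially unchanged. Compound 3 has another core; the difference between the two cores is not broken down here. In this assay compound 3 stands highest of the three numbers, well beyond the scatter from the other two.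

Compound 4 `CCCCCOCCCC1Cc2ccc(OC)cc2C(=O)O1` has not been measured. It differs from compound 3 by pentyl in place of hydrogen on an oxygen on a saturated carbon, the same change as that from compound 1 to compound 2. Because the earlier step gave a 1.0-fold lower number from compound 1 to compound 2 (0.01 log units; within the scatter), the step expected here is also small: a 1.1-fold lower number from compound 3 to compound 4 (0.02 log units; within the scatter). Compound 4 is therefore estimated at 125 ug/mL, most likely between 55 ug/mL and 280 ug/mL.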

Compound 4, concentration for 50% growth inhibition: 43.5 ug/mL
Compound 4: middle estimate off by 2.9-fold (0.46 log units), on the high side; measured number outside the range, below it.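

Pentyl in place of hydrogen on an oxygen on a saturated carbon gives a 3.0-fold lower number from compound 3 to compound 4 (0.48 log units; beyond the scatter), which means stronger inhibition of growth on this core. The same change left the number essentially unchanged on the core of compound 1, so its effect did not carry over from one core to the other: the same change on two cores in this assay, a 1.0-fold lower number (0.01 log units; within the scatter) from compound 1 to compound 2 and a 3.0-fold lower number (0.48 log units; beyond the scatter) from compound 3 to compound 4, 3.0-fold (0.47 log units) apart, beyond the scatter of two such steps. This shows that the outcome of the change depends on the core, but with one pair on each core it does not show why the cores differ or whether other changes would behave the same way.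

From the compounds shown here alone, it remains open how a shorter chain such as ethyl or a longer chain such as octyl would behave on each core. Going by these compounds, an amine or a carboxylic acid in place of the hydroxy group is equally open.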